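Pyridin-2-yl in place of pyrimidin-2-yl on compound 1

The source may report more compounds than this note shows. Statements on the series, on what has been measured and on what is new or still open speak of the compounds shown alone.

Measured in an ADME assay on cells (Hepatocyte, Homo sapiens) for metabolic stability; a lower number here means that the compound disappears faster, a higher number that the compound lasts longer:
compound 1 `O=C(C1CCN(c2ncccn2)CC1)N1N=CC[C@H]1c1ccccc1`: > 3.11 h
compound 2 `N#Cc1ccc(N2CCC(C(=O)N3N=CC[C@H]3c3cc(F)cc(F)c3)CC2)nn1`: > 8 h
compound 3 `CC1=NN(C(=O)C(C)(C)C)[C@H](c2ccccc2)C1`: 0.617 h

Compound 1 is reported only as a limit, > 3.11 h, and not as a number. Its entry stands as the limit of > 3.11 h in this assay, at which 1 of the 3 values shown sits. Compound 2 is likewise reported only as a limit, > 8 h. Compound 3 alone has a plain number, 0.617 h. Among the compounds with values here, compound 1 therefore has no exact place among the three, and no pair of measured compounds differs in just one place.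

Compound 4 `O=C(C1CCN(c2ccccn2)CC1)N1N=CC[C@H]1c1ccccc1` keeps the core of compound 1 and changes one group: pyridin-2-yl in place of pyrimidin-2-yl on an amine nitrogen in a ring. In words, pyridin-2-yl stands in place of pyrimidin-2-yl on an amine nitrogen in a ring. Within the data shown here, with no measured step to draw on, the only anchor for this expectation is compound 1 at > 3.11 h, which is a limit. A modest downward step in this assay is expected, of a size close to the usual scatter. The estimated change is an at least 1.2-fold lower number from compound 1 to compound 4 (0.09 log units; that floor lies within the scatter). For compound 4 the expected half-life is 2.5 h, with an estimated range from 1 h to 6 h.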

Compound 4, half-life: > 3.11 h
Compound 4: no number, only a limit; the forecaster's own chance of this, stated with the estimate: 30%; middle value at least 1.2-fold (0.09 log units) away from the limit.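

In this assay, compound 4 is reported only as a limit, > 3.11 h. Compound 1 is likewise only a limit, > 3.11 h, so no step can be read between the two compounds. Going by these compounds, it remains open how long either compound actually lasts, and whether pyridin-2-yl in place of pyrimidin-2-yl changes the half-life at all.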